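Aromatic Amide Replaced by Branched Alkyl Amide in Cytotoxicity

This account rests on a few compounds, and the source may have more. Where it says the series, first, only, none or still open, it means among the compounds named here.

Compound 1, `O=C(Nc1ccc2nc(NC(=O)C3CCCCC3)sc2c1)c1ccccc1C(F)(F)F`: 0.024 ug/mL
Compound 2, `O=C(Nc1ccc2nc(NC(=O)C3CCCCC3)sc2c1)c1cccc(F)c1`: 0.64 ug/mL
Compound 3, `N#Cc1cccc(C(=O)Nc2ccc3nc(NC(=O)C4CCCCC4)sc3c2)c1`: 0.52 ug/mL

In a functional assay on WI-38 VA13 cells (Homo sapiens) for cytotoxicity (a higher number here means that more compound is needed for the effect, a lower number that less compound is needed), compound 3 stands second highest of the three numbers; compound 2 sits within the scatter of it, while compound 1 lies far below. Compound 4, `CCC(C)(C)C(=O)Nc1ccc2nc(NC(=O)C3CCCCC3)sc2c1`, differs from compound 3 by 1,1-dimethylpropyl in place of 3-cyanophenyl on a carbonyl carbon. Among the measured compounds shown here, no measured step bears on this exchange directly: a 27-fold higher number from compound 1 to compound 2 (1.43 log units; beyond the scatter) and a 22-fold higher number from compound 1 to compound 3 (1.34 log units; beyond the scatter) trade one aromatic amide for another, and a 1.2-fold lower number from compound 2 to compound 3 (0.09 log units; within the scatter) stays within the scatter. With nothing to show how a chain in place of an aromatic ring behaves in this assay, a change near the scatter is expected, with wide uncertainty. Compound 4 is estimated at 0.8 ug/mL, between 0.15 ug/mL and 4 ug/mL. This estimate means an expected step of a 1.5-fold higher number from compound 3 to compound 4 (0.19 log units; within the scatter).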

Compound 4, half-maximal effective concentration: 1 ug/mL
The estimate for compound 4 lay 1.3-fold (0.10 log units) below the measured number; low and high end bracket the measured number.
By their numbers in this assay, from the lowest: compound 1; then compounds 3, 2 and 4 (each within the scatter of the next).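

In this assay the 1,1-dimethylpropyl group shows that this carbonyl carbon need not carry an aromatic ring: with a 1.9-fold higher number from compound 3 to compound 4 (0.28 log units; within the scatter) and a 1.6-fold higher number from compound 2 to compound 4 (0.19 log units; within the scatter) the chain stays level with the 3-cyanophenyl and 3-fluorophenyl amides. Only the 2-(trifluoromethyl)phenyl amide stands apart, with a 42-fold higher number from compound 1 to compound 4 (1.62 log units; beyond the scatter) as the step to the chain. Nothing given here explains these numbers. Open, going by these compounds, is whether a longer chain, an amine or a carboxylic acid on this carbonyl carbon would stay level with compound 4 too.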